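Extending the selenium substituent from methyl to benzyl

The source may hold more compounds than are shown below. What is called first, only, known or untested is meant among the compounds shown, and "the series" means these compounds.

Of the compounds shown here, three have been tested so far in a functional assay on MCF7 cells (Homo sapiens) for cytotoxicity, read by MTT assay, with a stated time of 72 h; on this read-out higher numbers stand for weaker inhibition of growth and lower numbers for stronger inhibition of growth. Compound 1, with the structure `C[Se]/C(=N\C(=O)c1cccs1)NC(=O)c1cccs1`, gives 3.4 nM in this assay. Compound 2, with the structure `CS/C(=N\C(=O)c1cc(-c2ccccc2)nc2ccccc12)NC(=O)c1cc(-c2ccccc2)nc2ccccc12`, gives 43100 nM in this assay. Compound 3, with the structure `C[Se]/C(=N\C(=O)c1cnc2ccccc2c1)NC(=O)c1cnc2ccccc2c1`, gives 660 nM in this assay. Among these three numbers compound 3 holds the second highest; the number of compound 2 is higher than that of compound 3 and the number of compound 1 is lower, and both gaps are wide enough to lie beyond the usual scatter of repeated measurements. Among the compounds with values here, no pair of these three compounds differs in only one place, so none of the gaps can be tied to a single structural change.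

Compound 4, with the structure `O=C(/N=C(/NC(=O)c1cnc2ccccc2c1)[Se]Cc1ccccc1)c1cnc2ccccc2c1`, keeps the core of compound 3 and differs from it in one place: phenyl in place of hydrogen on a saturated chain carbon bound to a selenium atom. Within the data shown here, nothing among the measured compounds shows what this change does on its own, so the expectation is kept modest. The step from compound 3 to compound 4 in this assay is estimated at a 1.5-fold higher number from compound 3 to compound 4 (0.18 log units; within the scatter), a change of uncertain direction. Compound 4 is accordingly expected to give about 1000 nM in this assay, within a range from 150 nM to 6000 nM.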

Compound 4, concentration for 50% growth inhibition: 23600 nM
The estimate for compound 4 lay 24-fold (1.37 log units) below the measured number; measured number above the stated range.
By their numbers in this assay, from the lowest: compound 1; then compound 3; then compounds 4 and 2 (each within the scatter of the next).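

Within the data shown here, this is the first step that can be tied to a single change, and it shows that this position is far from indifferent: in this assay, phenyl in place of hydrogen on a saturated chain carbon bound to a selenium atom, which turns methyl into benzyl, gives a 36-fold higher number from compound 3 to compound 4 (1.55 log units; beyond the scatter). On the core of compound 3, then, benzyl goes with much weaker inhibition of growth than methyl, and the size of the step lies well beyond the scatter of repeated measurements. No separate measurement bears on why the change has so large an effect, so the result stands as an observation without an explanation.

A single pair cannot show whether the weaker inhibition follows from any extension of the methyl group or from the phenyl ring itself, and an ethyl group or a longer saturated chain in the same place would help separate the two. Going by these compounds, it also remains open whether benzyl would produce a step of similar size on the core of compound 1, which carries methyl and gives the lowest number so far.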